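Bromo to Trifluoromethyl on a Shared Indazole-Free Core Description

The source may report more compounds than this note shows. Statements on the series, on what has been measured and on what is new or still open speak of the compounds shown alone.

Of the compounds shown here, two have been measured so far in an assay for inhibition of Tryptophan 2,3-dioxygenase (Homo sapiens), with stated times of 10 min and 60 min, tested at 10 uM; on this read-out higher numbers stand for a stronger effect at the one concentration tested and lower numbers for a weaker effect. Compound 1, with structure `Oc1ccc(CNc2cc(C(F)(F)F)cc3[nH]ncc23)cc1`, gives 75% in this assay. Compound 2, with structure `O=[N+]([O-])c1ccc(CNc2cc(Br)cc3[nH]ncc23)cc1`, gives 87% in this assay and thus stands highest of the two numbers, with compound 1 as its nearest neighbour at a value that lies beyond the usual scatter below it.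

Compound 3, with structure `O=[N+]([O-])c1ccc(CNc2cc(C(F)(F)F)cc3[nH]ncc23)cc1`, has not yet been measured. It differs from compound 2 in a single place: trifluoromethyl in place of bromo on an aromatic carbon. Going by the values given here, no step between measured compounds isolates this change, so its effect in this assay has to be gauged indirectly. Compound 1 carries the same trifluoromethyl but differs from compound 3 elsewhere as well, so its value only loosely suggests where compound 3 might land.

The step from compound 2 to compound 3 is expected to be small, a number 7 percentage points lower from compound 2 to compound 3 (within the scatter), pointing gently downward or lying within the scatter. Compound 3 is therefore estimated to give 80% in this assay, within a range from 62% to 93%.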

Compound 3, a percentage reported as inhibition, at one concentration (the size of the read-out at that concentration, not a potency): 47%
Estimate against measurement, compound 3: 33 percentage points above, outside the stated range (below it).
By their numbers in this assay, from the lowest: compound 3; then compound 1; then compound 2.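

At the aromatic carbon that carries bromo in compound 2, the new result shows that the group there matters strongly in this assay: with nitro kept in place, trifluoromethyl in place of bromo gives a number 40 percentage points lower from compound 2 to compound 3 (beyond the scatter) and so the two groups are not interchangeable at this position in this pair. Going by these compounds alone, compound 3 also provides the first single-change comparison for the other substituent, since with trifluoromethyl kept in place, nitro in place of hydroxy gives a number 28 percentage points lower from compound 1 to compound 3 (beyond the scatter) and shows that this change also matters on the shared core. No measurement here gives a reason for either step.

The compounds shown leave open whether the loss on moving from bromo to trifluoromethyl holds only alongside nitro or also alongside hydroxy, as the shared core with hydroxy and bromo together lies outside them. They also leave open how chloro, an amine or a carboxylic acid on this aromatic carbon would compare with bromo and trifluoromethyl on the same core.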